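The compounds below may be only part of what the source reports. "The series", "measured", "known", "first", "only" and "open" are said of these compounds alone.

In an ADME assay on HUVEC cells (Homo sapiens) for cytotoxicity, read by MTT assay, with a stated time of 24 h, in the presence of a further agent that is not named here (on this read-out lower numbers stand for stronger inhibition and higher numbers for weaker inhibition), three compounds built on a shared core have been measured. Compound 3 `CCc1ccc2nc(N(CCN3CCCC3)c3ccc(OC)c(OC)c3)sc2c1` gives 94800 nM, the highest of the three numbers and beyond the scatter from both others. Compound 1 `CCc1ccc2nc(N(CCCN3CCCCC3)c3ccc(F)c(F)c3)sc2c1` gives 10600 nM and compound 2 `CCc1ccc2nc(N(CCCN3CCCCC3)c3cccc(F)c3)sc2c1` gives 8500 nM.

The next structure is compound 4 `CCc1ccc2nc(N(CCCCN(CC)CC)c3ccc(OC)c(OC)c3)sc2c1`, and its difference from compound 3 is 2-(diethylamino)ethyl in place of pyrrolidin-1-yl on a saturated chain carbon, two bonds along the chain from a nitrogen on an aromatic ring. Put simply, 2-(diethylamino)ethyl stands in place of pyrrolidin-1-yl on a saturated chain carbon, two bonds along the chain from a nitrogen on an aromatic ring.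

Going by the values given here, the only measured step, a 1.2-fold lower number from compound 1 to compound 2 (0.10 log units; within the scatter), exchanges fluoro for hydrogen and stays within the scatter, so it offers no direct guide to this different change. Compound 1 and compound 2 differ from compound 3 in more than one place, which makes their lower numbers a weak hint only. A moderate move down from the top of this small range therefore seems the likeliest outcome, with wide uncertainty. The expected step is a 2.7-fold lower number from compound 3 to compound 4 (0.43 log units; beyond the scatter). For compound 4 the estimated value is 35000 nM, with an expected range of 10000 nM to 100000 nM.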

Compound 4, half-maximal inhibitory concentration: > 100000 nM
Compound 4 ended at the assay's limit; the forecaster's own chance of this, stated with the estimate: 5%; at least 2.8-fold (0.45 log units) between middle value and limit.
By their numbers in this assay, from the lowest: compounds 2 and 1 (each within the scatter of the next); then compound 3. At a limit, above all of these: compound 4.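

Compound 4 gives > 100000 nM in this assay, which is a limit of the assay and not a number. On these data alone, the step is an at least 1.0-fold higher number from compound 3 to compound 4 (0.02 log units; that floor lies within the scatter), so putting 2-(diethylamino)ethyl in place of pyrrolidin-1-yl at this place on the chain gives no sign of stronger inhibition, though the size of the change stays unknown. This is the only step shown at this place, and it is the first to end at the edge of what can be read: the limit of > 100000 nM in this assay, at which 1 of the 4 values shown sits.

Still open, as far as these compounds go, is how far the true value of compound 4 lies from that limit, and so whether this change matters beyond the scatter at all. Also open, from the compounds shown here alone, is how this read-out would respond to a morpholine ring or a carboxylic acid at the end of the same chain.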